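The source may report more compounds than this note shows. Statements on the series, on what has been measured and on what is new or still open speak of the compounds shown alone.

Compound 1 `N#CC1=C(N)OC(c2c[nH]c3ccccc23)=C(C#N)C1c1ccccc1F` and compound 2 `COc1ccc(C2C(C#N)=C(N)OC(c3c[nH]c4ccccc34)=C2C#N)cc1OC` share one core and differ only in the aryl group on a saturated ring carbon. In a functional assay on MCF7 cells (Homo sapiens) for cytotoxicity, read by MTT assay, with a stated time of 24 h (a lower number here means that less compound is tolerated, a higher number that more compound is tolerated), compound 1 reaches no number but a limit, > 100000 nM, which is the limit of > 100000 nM in this assay, at which 1 of the 2 values shown sits. In this assay, among the measured compounds shown here, compound 2 gives 72100 nM, the only number among the two values shown. The step of an at least 1.3-fold lower number from compound 1 to compound 2 (0.14 log units; that floor lies within the scatter) lies within the scatter. Compound 3 `N#CC1=C(N)OC(c2c[nH]c3ccccc23)=C(C#N)C1c1cccc2ccccc12` carries naphthalen-1-yl in place of 3,4-dimethoxyphenyl on a saturated ring carbon. For the measured compounds named here, the one measured exchange of this aryl group was small, so no step beyond the scatter is expected in this assay. Compound 3 is estimated at 70000 nM, between 30000 nM and 150000 nM. That estimate means a step of a 1.0-fold lower number from compound 2 to compound 3 (0.01 log units; within the scatter).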

Compound 3, concentration lethal to 50% of the cells: 80200 nM
Estimate against measurement, compound 3: 1.1-fold (0.06 log units) below, and the stated range covers the measured number.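

In this assay, naphthalen-1-yl, which is all carbon, stands on this saturated ring carbon in place of 3,4-dimethoxyphenyl with a 1.1-fold higher number from compound 2 to compound 3 (0.05 log units; within the scatter), so removing both oxygens of that group leaves the read-out within the scatter. The exchange of 2-fluorophenyl for naphthalen-1-yl gives only a floor, an at least 1.2-fold lower number from compound 1 to compound 3 (0.09 log units; that floor lies within the scatter). Compound 1 remains a limit: the limit of > 100000 nM in this assay, at which 1 of the 3 values shown sits.

From the compounds shown here alone, whether an amine or a carboxylic acid on the aryl group would give a step beyond the scatter remains open. Going by these compounds, the 1H-indol-3-yl and amino groups are the same in all three compounds, so what they contribute is also open.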